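A Larger Ring Group, Tested Without a Measured Neighbour

The source may hold more compounds than are shown below. What is called first, only, known or untested is meant among the compounds shown, and "the series" means these compounds.

In an ADME assay on microsomes from liver (Mus musculus) for metabolic stability, with a stated time of 10 min (a higher number here means that more of the compound is left, a lower number that less of the compound is left), compound 1 `O=C(O)C1CCC(O)(C(=O)N2CC[C@](c3ccc(C(F)(C(F)(F)F)C(F)(F)F)cc3)(S(=O)(=O)c3ccc(F)cc3)C2)CC1` gives 99%; 98% (2 entries). Compound 2 `O=C(O)C12CCC(C(=O)N3CC[C@](c4ccc(C(F)(C(F)(F)F)C(F)(F)F)cc4)(S(=O)(=O)c4ccc(F)cc4)C3)(CC1)C2` offers no number to compare, since the entry for compound 2 reads "not determined" (no result reported). Compound 3 `O=C(O)C12CCC(C(=O)N3CC[C@](c4ccc(C(F)(C(F)(F)F)C(F)(F)F)cc4)(S(=O)(=O)c4ccc(F)cc4)C3)(CC1)CC2` changes compound 2 on a carbonyl carbon whose other neighbour is an amide-type nitrogen in a ring: a group of 11 heavy atoms (9 carbon, 2 oxygen; 2 six-membered non-aromatic rings of carbon only) in place of a group of 10 heavy atoms (8 carbon, 2 oxygen; 2 five-membered non-aromatic rings of carbon only), on a carbonyl carbon. Among the measured compounds shown here, no measured step shows what this swap does, so no shift beyond the usual scatter is expected in this assay, and the only anchor is compound 1 at 99%; 98% (2 entries). For compound 3, the estimated value is 90%, with an expected range from 72% to 100%.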

Compound 3, percent of the compound remaining: 73%
Beside the measured number, compound 3's estimate is 17 percentage points above it, and the stated range covers the measured number.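

Among the compounds shown here, compound 2 has no number in this assay, so no step from compound 2 to compound 3 can be read. The compounds shown leave open what this swap of ring groups does to the amount of compound remaining, and nothing shown explains the result for compound 3.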